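Adding a trifluoromethyl group to an anilide in a dopamine series

The compounds below may be only part of what the source reports. "The series", "measured", "known", "first", "only" and "open" are said of these compounds alone.

Measured so far:
compound 1 `O=C(CN1CCC(c2cccc[n+]2[O-])CC1)Nc1cccc(F)c1` gives 160 nM
compound 2 `O=C(CN1CCC(c2cccc[n+]2[O-])CC1)Nc1ccc(F)cc1` gives 85 nM

Both compounds were tested in a functional assay on HEK293 cells for agonist activity at D(4) dopamine receptor (Homo sapiens), read by FLIPR; a lower number here means that less compound is needed, a higher number that more compound is needed for the effect. Among the measured compounds shown here, compound 2 has the lowest of the two numbers, but the only step measured, a 1.9-fold lower number from compound 1 to compound 2 (0.27 log units; within the scatter), lies within the scatter, so the two compounds cannot be told apart on these data.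

Compound 3 `O=C(CN1CCC(c2cccc[n+]2[O-])CC1)Nc1ccc(F)cc1C(F)(F)F` differs from compound 2 by one change: trifluoromethyl in place of hydrogen on an aromatic carbon. For the measured compounds named here, nothing among the measured compounds resembles this step. Going by the values given here, the single measured step concerns moving a fluoro group around the same ring, not adding a second group, so it gives no direct guide to the size or direction of the effect here. In the absence of a comparable step, the most reasonable expectation is that compound 3 stays close to compound 2, with wide uncertainty in both directions. Compound 3 is therefore expected to give about 120 nM, in a range from 30 nM to 500 nM, which corresponds to an estimated step of a 1.4-fold higher number from compound 2 to compound 3 (0.15 log units; within the scatter).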

Compound 3, half-maximal effective concentration: 473 nM
Estimate against measurement, compound 3: 3.9-fold (0.60 log units) below; the measured number falls inside the stated range.
By their numbers in this assay, from the lowest: compounds 2 and 1 (each within the scatter of the next); then compound 3.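

In this assay, trifluoromethyl in place of hydrogen on this aromatic carbon, ortho to a large group and meta to a fluoro group, gives a 5.6-fold higher number from compound 2 to compound 3 (0.75 log units; beyond the scatter). Among the compounds shown here, this is the first change that lies beyond the scatter, so it shows that the anilide ring can respond to substitution, whereas the earlier move of the fluoro group could not be told apart from repeat-to-repeat noise. Here, adding this group means that more compound is needed for the same effect, but nothing available explains the reason for this step.

The compounds shown leave open whether any added group on this carbon raises the number or whether this is specific to trifluoromethyl, a question that a methyl group, a chlorine atom or a methoxy group at the same place could help to settle. They also leave open whether trifluoromethyl would produce a step of similar size and direction on the ring of compound 1, where the fluoro group sits elsewhere.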